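The compounds below may be only part of what the source reports. "The series", "measured", "known", "first", "only" and "open" are said of these compounds alone.

Measured so far:
- compound 1, `Nc1scc(CN2CCN(c3ccc(Cl)cc3F)CC2)c1C(=O)c1ccc(Cl)cc1`: -81%
- compound 2, `Nc1scc(CN2CCN(c3c(F)cc(F)cc3F)CC2)c1C(=O)c1ccc(Cl)cc1`: -78%

In a functional assay on CHO cells with adenosine receptor A1 (Homo sapiens) as the target, read by cAMP accumulation and immunoassay, with a stated time of 6 min, tested at 10 uM (on this read-out higher numbers stand for a weaker effect at the one concentration tested and lower numbers for a stronger effect), compound 1 gives -81% and compound 2 gives -78%; the two values lie within the usual scatter of one another, so neither can be placed above the other on these numbers. For the measured compounds named here, the only measured step, a number 3 percentage points higher from compound 1 to compound 2 (within the scatter), exchanges one aryl group for another on the amine nitrogen in the ring of the shared core and stays within the scatter.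

Compound 3, `Nc1scc(CN2CCN(c3ccc(Cl)c(Cl)c3)CC2)c1C(=O)c1ccc(Cl)cc1`, is not yet measured. It differs from compound 2 by 3,4-dichlorophenyl in place of 2,4,6-trifluorophenyl on an amine nitrogen in a ring. The step from compound 1 to compound 2 is the one that bears on this change, since it alters the same group at the same place, and it was within the scatter. The expected step for compound 3 in this assay is therefore a number 1 percentage points lower from compound 2 to compound 3 (within the scatter), none beyond the scatter. Compound 3 is estimated at -79%, with a range from -92% to -62%.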

Compound 3, a percentage reported as activity, at one concentration (the size of the read-out at that concentration, not a potency): -62%
For compound 3 the middle estimate is 17 percentage points below the measured one; the measured number falls inside the stated range.
By their numbers in this assay, from the lowest: compounds 1 and 2 (each within the scatter of the next); then compound 3.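

In this assay the aryl group on the amine nitrogen in a ring now shows a step beyond the scatter: 3,4-dichlorophenyl gives a number 16 percentage points higher from compound 2 to compound 3 (beyond the scatter) in place of 2,4,6-trifluorophenyl and a number 19 percentage points higher from compound 1 to compound 3 (beyond the scatter) in place of 4-chloro-2-fluorophenyl, both toward a weaker effect at the one concentration tested. For the compounds shown here, the earlier exchange at this position stayed within the scatter, so these are the first steps to show that the read-out responds to the aryl group here. Nothing available bears on why this group gives the weaker effect.

Whether the steps go with the two chlorine atoms together or with the absence of fluorine cannot be told from these three compounds. From the compounds shown here alone, how an unsubstituted phenyl or a methoxyphenyl on the same nitrogen would read remains open.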